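Notes: 4-chlorophenyl in place of cyclopropyl in compound 2

A few compounds are considered here, and "the series" means these few. Any claim that something is new, unique, unknown or untested is made for them only; others in the source may bear on it.

Measured in a functional assay on MOLT-4 cells (Homo sapiens) for antiproliferative activity, read by MTT assay, with a stated time of 48 h; on this read-out lower numbers stand for stronger inhibition and higher numbers for weaker inhibition:
- compound 1 `O=C(CCCCCn1cc(Nc2ncc(Cl)c(Nc3ccc(Cl)cc3)n2)cn1)NO`: 80 nM
- compound 2 `O=C(CCCCCCn1cc(Nc2ncc(Cl)c(NC3CC3)n2)cn1)NO`: 150 nM

Compound 1 and compound 2 at 150 nM stand within the scatter of each other, so these numbers do not separate the two. Compound 3 `O=C(CCCCCCn1cc(Nc2ncc(Cl)c(Nc3ccc(Cl)cc3)n2)cn1)NO` has not yet been measured. It keeps the chain of compound 2 and differs from it in one place: 4-chlorophenyl in place of cyclopropyl on a nitrogen on an aromatic ring. In words, this is 4-chlorophenyl in place of cyclopropyl on a nitrogen on an aromatic ring.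

Among the compounds with values here, no measured pair shows this change alone. Compound 1 also carries the 4-chlorophenyl group and gives 80 nM, but its chain differs from that of compound 2, so it is only a rough guide. In this assay a small move to a lower number is expected, about the size of the scatter and not clearly beyond it, and the estimated change is a 2.0-fold lower number from compound 2 to compound 3 (0.30 log units; within the scatter). Compound 3 is expected at 75 nM, with an estimated range of 25 nM to 220 nM.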

Compound 3, half-maximal inhibitory concentration: 120 nM
Estimate against measurement, compound 3: 1.6-fold (0.20 log units) below; measured number inside the range.
By their numbers in this assay, from the lowest: compounds 1, 3 and 2 (each within the scatter of the next).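

In this assay, the change from cyclopropylamino to (4-chlorophenyl)amino can now be read on its own, as a 1.3-fold lower number from compound 2 to compound 3 (0.10 log units; within the scatter); the larger group, with its six-membered aromatic ring in place of a three-membered ring, gives no difference that these numbers can separate at this position. Compound 3 also makes the chain comparable with the 4-chlorophenyl group held constant, and a 1.5-fold higher number from compound 1 to compound 3 (0.18 log units; within the scatter) shows that (hydroxycarbamoyl)methyl in place of hydroxycarbamoyl on a saturated chain carbon, five bonds along the chain from an aromatic nitrogen, is likewise not separated from the scatter. No measurement at hand gives a reason for either result.

On these data alone, whether a phenyl without chlorine, a 4-methoxyphenyl or a saturated amine such as morpholine on the same nitrogen would give a step beyond the scatter remains open. As far as these compounds go, it is also open whether a longer chain, or a carboxylic acid in place of the hydroxycarbamoyl group, would separate from these compounds in this assay.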